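A few compounds are considered here, and "the series" means these few. Any claim that something is new, unique, unknown or untested is made for them only; others in the source may bear on it.

Compound 1 `CCCS(=O)(=O)Nc1ccc(F)c(C(=O)c2n[nH]c3ncc(-c4ccc(S(=O)(=O)NC)cc4)cc23)c1F` and compound 2 `CCCS(=O)(=O)Nc1ccc(F)c(C(=O)c2n[nH]c3ncc(-c4ccc(S(=O)(=O)NCC)cc4)cc23)c1F` share one core and differ only at a sulfonamide nitrogen. In an assay for binding affinity to dual specificity mitogen-activated protein kinase kinase 4 (Homo sapiens), read by KINOMEscan, tested at 100 nM (a lower number here means a stronger effect, a higher number a weaker effect of the compound at the concentration tested), compound 1 gives 1.2%, while compound 2 gives 3%, a step of a number 1.8 percentage points higher from compound 1 to compound 2 (within the scatter) that does not separate the two. Compound 3 `CCCS(=O)(=O)Nc1ccc(F)c(C(=O)c2n[nH]c3ncc(-c4ccc(S(=O)(=O)NC(C)=O)cc4)cc23)c1F` arises from compound 2 by acetyl in place of ethyl on a sulfonamide nitrogen. For the measured compounds named here, the one measured step at this nitrogen was small, so little change is expected, and for compound 3 the expected step is a number 3 percentage points higher from compound 2 to compound 3 (within the scatter). Compound 3 is therefore estimated at 6%, within 1% to 25%.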

Compound 3, a percentage reported as activity, at one concentration (the size of the read-out at that concentration, not a potency): 0.35%
The estimate for compound 3 lay 5.7 percentage points above the measured number, and the stated range ends above it.
By their numbers in this assay, from the lowest: compounds 3, 1 and 2 (each within the scatter of the next).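

In this assay, acetyl in place of ethyl gives a number 2.7 percentage points lower from compound 2 to compound 3 (within the scatter), and acetyl in place of methyl gives a number 0.9 percentage points lower from compound 1 to compound 3 (within the scatter). On this sulfonamide nitrogen, then, a group with a carbonyl and a plain alkyl chain cannot be told apart, which the two alkyl compounds alone could not show. Nothing available explains this result.

On these data alone, whether a longer chain, a benzoyl group or a chain ending in an amine would raise the number remains open. Readings this low at one concentration also leave any ranking of the three compounds open.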